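The compounds below may be only part of what the source reports. "The series", "measured", "known", "first", "only" and "open" are said of these compounds alone.

Working notes on the series. Compound 1 `C=Cc1cn2ncc(-c3ccnc(OC)c3)c2nc1NC` and compound 2 `COc1cc(-c2cnn3cc(OC)c(C(C)(C)O)nc23)ccn1` share the core; in an assay on isolated protein for inhibition of activin receptor type-2A (Homo sapiens), read by 33P incorporation, with a stated time of 20 min, in the presence of a further agent that is not named here (on this read-out lower numbers stand for stronger inhibition and higher numbers for weaker inhibition), compound 1 gives 190 nM, while compound 2 gives 2700 nM, the highest of the two numbers recorded, beyond the scatter from compound 1. Compound 3 `COc1cc(-c2cnn3cc(OC)c([C@H]4COC(C)(C)C4)nc23)ccn1` is not yet measured. It differs from compound 2 by a group of 7 heavy atoms (6 carbon, 1 oxygen; one five-membered non-aromatic ring with 1 hetero atom) in place of a group of 4 heavy atoms (3 carbon, 1 oxygen; no ring), on an aromatic carbon. Within the data shown here, no measured pair shows this kind of change, so the size of the step is uncertain; the expected step of a 1.8-fold lower number from compound 2 to compound 3 (0.26 log units; within the scatter) in this assay is small and may not exceed the scatter. For compound 3 the estimate in this assay is 1500 nM, within 400 nM to 6000 nM.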

Compound 3, half-maximal inhibitory concentration: 4100 nM
Compound 3: middle estimate off by 2.7-fold (0.44 log units), on the low side; measured number inside the range.
By their numbers in this assay, from the lowest: compound 1; then compounds 2 and 3 (each within the scatter of the next).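

In this assay the exchange of 1-hydroxy-1-methylethyl for the larger ring-bearing group on this aromatic carbon gives a 1.5-fold higher number from compound 2 to compound 3 (0.18 log units; within the scatter). Going from 1 hydrogen-bond donor to 0 at this position, with a five-membered non-aromatic ring and a defined stereocentre added, thus produces no change beyond the scatter. No available evidence bears on this result.

The compounds shown leave open how an amine or a carboxylic acid on this aromatic carbon would read, and whether the opposite stereoisomer of the ring group would read alike. The gap to compound 1 cannot be assigned to one place, as compound 1 differs from the other two in more than one place.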